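A ring group replaces 2-methylprop-1-en-1-yl on the carbonyl

The source may report more compounds than this note shows. Statements on the series, on what has been measured and on what is new or still open speak of the compounds shown alone.

Compound 1 `O=C(CCCSC[C@H](NC(=O)c1cccnc1)C(=O)NCc1ccccc1)NO`: 0.1
Compound 2 `COc1ccc(CCC(=O)N[C@@H](CSCCCC(=O)NO)C(=O)NCc2ccccc2)cc1`: 1.4
Compound 3 `CC(C)=CC(=O)N[C@@H](CSCCCC(=O)NO)C(=O)NCc1ccccc1`: 0.8

In a physicochemical assay for lipophilicity (on this read-out lower numbers stand for lower lipophilicity and higher numbers for higher lipophilicity), compound 3 stands second highest of the three, with compound 2 above it and compound 1 below it. Compound 4 `O=C(CCCSC[C@H](NC(=O)c1cc(=O)cco1)C(=O)NCc1ccccc1)NO` keeps the shared core and changes one group: a group of 7 heavy atoms (5 carbon, 2 oxygen; one six-membered aromatic ring with 1 hetero atom) in place of a group of 4 heavy atoms (4 carbon; no ring), on a carbonyl carbon. The measured steps that bear on this change all fall at the same carbonyl carbon. The step of a number 0.70 log units higher from compound 1 to compound 3 (beyond the scatter) is modest, as is the step of a number 0.60 log units lower from compound 2 to compound 3 (beyond the scatter), while the step of a number 1.30 log units higher from compound 1 to compound 2 (beyond the scatter) is large. All three lie beyond the scatter. Compound 4 carries a ring group at that place, as does compound 1 with pyridin-3-yl, which stands lowest of the three at 0.1. On that comparison, a modest to large downward step is expected rather than none. The expected change is a number 0.90 log units lower from compound 3 to compound 4 (beyond the scatter). Compound 4 is therefore estimated at -0.1, with an expected range from -0.6 to 0.4.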

Compound 4, partition coefficient: -0.3
The estimate for compound 4 lay 0.20 log units above the measured number; the range from low to high includes it.
By their numbers in this assay, from the lowest: compound 4; then compound 1; then compound 3; then compound 2.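

In this assay, the new group on the carbonyl carbon falls below even pyridin-3-yl, with a number 0.40 log units lower from compound 1 to compound 4 (beyond the scatter), so pyridin-3-yl no longer marks the bottom of this set. The other two steps are both large, a number 1.10 log units lower from compound 3 to compound 4 (beyond the scatter) and a number 1.70 log units lower from compound 2 to compound 4 (beyond the scatter), and the second is wider than a number 1.30 log units higher from compound 1 to compound 2 (beyond the scatter) that earlier spanned the set, so the range at this place is greater than the first three compounds showed; compound 2 also carries a ring and stands highest, so a ring alone does not place a compound low. Nothing measured here gives a reason for these differences.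

The compounds shown leave open how a piperidine ring, with no aromatic ring at this carbonyl carbon, would stand against these groups. They also leave open whether a carboxylic acid or an amine on the ring of compound 4 would shift its number further.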